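From propylamino to diethylamino on the shared core

The source may hold more compounds than are shown below. What is called first, only, known or untested is meant among the compounds shown, and "the series" means these compounds.

For the measured compounds named here, in a functional assay on the whole organism with Rattus norvegicus as the target (on this read-out lower numbers stand for an effect already at smaller amounts and higher numbers for an effect only at larger amounts of compound), compound 2 `CCCNc1cccc(NC(=O)C(=O)OCC)c1C#N` gives 0.5 mg/kg and so holds the lower of the two numbers known, with compound 1 `CCOC(=O)C(=O)Nc1cccc(OC)c1C#N` at 5.3 mg/kg on the same read-out. Compound 3 `CCOC(=O)C(=O)Nc1cccc(N(CC)CC)c1C#N` differs from compound 2 by diethylamino in place of propylamino on an aromatic carbon on an aromatic carbon ortho to a cyano group. Going by the values given here, the one measured step, an 11-fold lower number from compound 1 to compound 2 (1.03 log units; beyond the scatter) with propylamino in place of methoxy, is large and beyond the scatter, yet it does not compare two amino groups. A modest rise is expected, estimated as a 2.0-fold higher number from compound 2 to compound 3 (0.30 log units; within the scatter) at the edge of the scatter. Compound 3 is estimated at 1 mg/kg with 0.3 mg/kg to 3.5 mg/kg as the expected range.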

Compound 3, dose for half-maximal effect: 0.7 mg/kg
Compound 3: middle estimate off by 1.4-fold (0.15 log units), on the high side, within the range that was stated.
By their numbers in this assay, from the lowest: compounds 2 and 3 (each within the scatter of the next); then compound 1.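

In this assay, the step of a 1.4-fold higher number from compound 2 to compound 3 (0.15 log units; within the scatter) lies within the scatter, so on this aromatic carbon ortho to a cyano group, the hydrogen-bond donor of propylamino is not needed to keep the low number. The step of a 7.6-fold lower number from compound 1 to compound 3 (0.88 log units; beyond the scatter) is beyond the scatter and shows that the advantage over methoxy is not confined to propylamino. Nothing at hand gives a reason for either step. The compounds shown leave open how an unsubstituted amine, a dimethylamino group or a longer chain such as dibutylamino would fare at this position.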